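Removing the hydroxy from the chain carbon of compound 2

The compounds below may be only part of what the source reports. "The series", "measured", "known", "first", "only" and "open" are said of these compounds alone.

Compound 1 `Cc1ccc(C(=O)N[C@@H]2[C@@H](O)[C@H](n3cnc4c(NC5CCCC5)ncnc43)O[C@@H]2CO)cc1F`: 773 nM
Compound 2 `O=C(CCCc1cccs1)N[C@@H]1[C@@H](O)[C@H](n2cnc3c(NC4CCCC4)ncnc32)O[C@@H]1CO`: 630 nM

In an assay on CHO cells for binding affinity to adenosine receptor A1 (Homo sapiens) (on this read-out lower numbers stand for stronger inhibition and higher numbers for weaker inhibition), compound 2 gives 630 nM, the lowest of the two numbers, with compound 1 nearest at a 1.2-fold lower number from compound 1 to compound 2 (0.09 log units; within the scatter). Compound 3 `C[C@H]1O[C@@H](n2cnc3c(NC4CCCC4)ncnc32)[C@H](O)[C@H]1NC(=O)CCCc1cccs1` differs from compound 2 by hydrogen in place of hydroxy on a saturated chain carbon bound to a saturated ring carbon. Among the measured compounds shown here, the only measured step, from compound 1 to compound 2, changes a different part of the molecule and gives no guide to this hydroxy. For the measured compounds named here, no measured pair speaks to the change itself. Compound 3 is expected to reach 1500 nM, with a range from 500 nM to 4500 nM. This estimate corresponds to a step of a 2.4-fold higher number from compound 2 to compound 3 (0.38 log units; beyond the scatter).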

Compound 3, inhibition constant: 419 nM
For compound 3 the middle estimate is 3.6-fold (0.55 log units) above the measured one; the whole stated range lies above it.
By their numbers in this assay, from the lowest: compounds 3, 2 and 1 (each within the scatter of the next).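

Hydroxymethyl to methyl, the first change measured at this position, gives a 1.5-fold lower number from compound 2 to compound 3 (0.18 log units; within the scatter) in this assay. In this pair, then, the number stays within the scatter without the hydroxy on the saturated chain carbon bound to a saturated ring carbon. Nothing shown accounts for this result.

As far as these compounds go, whether an amine, a methoxy or a carboxylic acid at the same place would also stay within the scatter remains open. So does whether hydroxymethyl to methyl reads the same alongside the 3-fluoro-4-methylphenyl of compound 1.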